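A few compounds are considered here, and "the series" means these few. Any claim that something is new, unique, unknown or untested is made for them only; others in the source may bear on it.

In a functional assay on the whole organism (strain albino) for inhibition, with Rattus norvegicus as the target, read by paw edema, with a stated time of 3 h, at a dose of 0.28 mmol/kg by the oral route (on this read-out higher numbers stand for more inhibition at the one dose given (going by the name of the read-out) and lower numbers for less inhibition), compound 3 `CCn1c(SCC(=O)c2ccccc2)nnc1-c1ccccc1` gives 61%. Compound 1 `C=CCn1c(SCC(=O)c2ccccc2)nnc1-c1ccccc1` gives 70% and compound 2 `O/N=C(/CSc1nnc(-c2ccccc2)n1-c1ccccc1)c1ccccc1` gives 65%, so compound 3 carries the smallest of the three numbers, yet each of the other two lies within the usual scatter of it, and no real order among the three can be read. For the measured compounds named here, the only measured step that changes one place at a time, a number 9 percentage points lower from compound 1 to compound 3 (within the scatter), is also within the scatter.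

Compound 4 `O=C(CSc1nnc(-c2ccccc2)n1-c1ccccc1)c1ccccc1` has not yet been measured. It differs from compound 3 by phenyl in place of ethyl on an aromatic nitrogen. Going by the values given here, no measured step follows this exact change. Compound 2 also bears a phenyl on the aromatic nitrogen and its number sits close to that of compound 3, but compound 2 differs from compound 4 in a second place as well, so only the two values themselves can be compared. In this assay the step expected from this change is a number 3 percentage points higher from compound 3 to compound 4 (within the scatter), nothing beyond the scatter. Compound 4 is expected to give 64%, with a range from 50% to 78%.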

Compound 4, a percentage reported as inhibition, in the whole organism at one dose (the size of the read-out at that dose, not a potency): 64%
Beside the measured number, compound 4's estimate shows no gap at the digits printed; measured number inside the range.
By their numbers in this assay, from the lowest: compounds 3, 4, 2 and 1 (each within the scatter of the next).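

For the compounds shown here, at this position on the aromatic nitrogen, phenyl in place of ethyl gives a number 3 percentage points higher from compound 3 to compound 4 (within the scatter), and phenyl in place of allyl gives a number 6 percentage points lower from compound 1 to compound 4 (within the scatter), so in this assay a ring on this nitrogen reads no differently from either open chain, something the one earlier step, between two chains, could not show. The change on the saturated chain carbon bound to the sulfur, with phenyl on the nitrogen in both compounds, gives a number 1 percentage points lower from compound 2 to compound 4 (within the scatter), so this second place also shows no step beyond the scatter. Nothing measured here offers an explanation for how close these numbers lie.

The compounds shown leave open whether a different group on this nitrogen, such as a longer chain, an amine or a carboxylic acid, would move the number beyond the scatter. With a single dose and a single time, they also leave any difference in potency unread.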